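Fluoromethyl removal along short fluorinated alcohol chains

The compounds below may be only part of what the source reports. "The series", "measured", "known", "first", "only" and "open" are said of these compounds alone.

Measured compounds:
compound 1, `OCCC(F)(F)CF`, 0.27
compound 2, `OCCC(F)F`, 0.04
compound 3, `OCCCC(F)CF`, 0.11

These three alcohols were measured in a physicochemical assay for lipophilicity, read by NMR; a higher number here means a more lipophilic compound, a lower number a more polar compound. From compound 1 to compound 2 the change is hydrogen in place of fluoromethyl on a saturated chain carbon bound to two fluorine atoms and a saturated chain carbon, and it gave a number 0.23 log units lower from compound 1 to compound 2 (within the scatter). Compound 4, `OCCCCF`, is not yet measured; it differs from compound 3 by hydrogen in place of fluoromethyl on a saturated chain carbon bound to a fluorine atom and a saturated chain carbon. The two changes are the same kind of change, though the place differs: in the first the carbon is bound to two fluorine atoms, in the second to a fluorine atom. The difference between the cores of compound 1 and compound 3 is not broken down here. Resting on compound 3 at 0.11 and on the step of a number 0.23 log units lower from compound 1 to compound 2 (within the scatter), the expected step is a number 0.23 log units lower from compound 3 to compound 4 (within the scatter). Compound 4 is estimated at -0.12, between -0.45 and 0.2.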

Compound 4, partition coefficient: 0.09
Estimate against measurement, compound 4: 0.21 log units below, within the range that was stated.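

In this assay the swap of hydrogen for fluoromethyl on a saturated chain carbon bound to a fluorine atom gave a number 0.02 log units lower from compound 3 to compound 4 (within the scatter) while on a saturated chain carbon bound to two fluorine atoms it gave a number 0.23 log units lower from compound 1 to compound 2 (within the scatter) so neither step stands clear of the usual scatter of repeated measurements. Going by these compounds alone, this shows no change that can be told from scatter on either core, but it does not show that the change has no effect, or that any step size carries from one core to another, with only two pairs to go on. Nothing available bears on these results.

The compounds shown leave open whether the step would hold in a series with an amine or a carboxylic acid in place of the alcohol. They also leave open how it would read on a longer chain.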